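A few compounds are considered here, and "the series" means these few. Any claim that something is new, unique, unknown or untested is made for them only; others in the source may bear on it.

Of the compounds shown here, three sharing one core have been measured so far in a functional assay on A549 cells (Homo sapiens) for antiproliferative activity, read by MTT assay, with a stated time of 72 h (a lower number here means a stronger inhibitor, a higher number a weaker inhibitor), and their values lie close together. Compound 1 `O=S1(=O)C=Cc2cccc(Nc3cccc(F)c3)c21` gives 2550 nM in this test, compound 2 `COc1ccccc1Nc1cccc2c1S(=O)(=O)C=C2` gives 2590 nM in the same test, and compound 3 `O=S1(=O)C=Cc2cccc(Nc3cc(C(F)(F)F)cc(C(F)(F)F)c3)c21` gives 3840 nM there as well. Compound 2 thus stands within the usual scatter of both others, and the three cannot be ranked. Compound 4 `O=S1(=O)C=Cc2cccc(Nc3ccccc3C(F)(F)F)c21` differs from compound 2 in one place, with trifluoromethyl in place of methoxy on an aromatic carbon, ortho to a large group (trifluoromethyl in place of methoxy on an aromatic carbon). No pair of measured compounds differs in one place only, so the size of this change has not been shown directly. Compound 3, which also carries trifluoromethyl, gives 3840 nM and stays within the scatter of compound 2 at 2590 nM in this assay. On that basis, the expected step of a 1.2-fold higher number from compound 2 to compound 4 (0.06 log units; within the scatter) stays within the scatter. For compound 4 the estimated value is 3000 nM with an expected range from 1400 nM to 6500 nM in this test.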

Compound 4, half-maximal inhibitory concentration: 4120 nM
For compound 4 the middle estimate is 1.4-fold (0.14 log units) below the measured one, within the range that was stated.
By their numbers in this assay, from the lowest: compounds 1, 2, 3 and 4 (each within the scatter of the next).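

For the compounds shown here, the step of a 1.6-fold higher number from compound 2 to compound 4 (0.20 log units; within the scatter) in this assay is the first direct reading of a single change, where the earlier compounds could be compared only across more than one difference. It shows that, on this aromatic carbon ortho to a large group, methoxy and trifluoromethyl cannot be told apart in this test, even though the entering group has more heavy atoms and no hydrogen-bond acceptor. No measured evidence bears on why the two compounds read alike.

Methoxy and trifluoromethyl are the only groups shown at this place, so it remains open whether an amine or a carboxylic acid there would also stay within the scatter. Going by these compounds, whether the same exchange would read alike on another carbon of that ring also remains open.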